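Series notes: replacing the four-membered ring on the amide nitrogen

The source may hold more compounds than are shown below. What is called first, only, known or untested is meant among the compounds shown, and "the series" means these compounds.

Of the compounds shown here, three have been measured in an assay on HEK293 cells for inhibition of N-acylethanolamine-hydrolyzing acid amidase (Rattus norvegicus), with a stated time of 30 min; on this read-out higher numbers stand for weaker inhibition and lower numbers for stronger inhibition. Compound 1 `O=C(CCc1ccccc1)N[C@H]1COC1=O` gives 420 nM and stands second highest of the three numbers. Compound 2 `O=C(CCCCCCc1ccccc1)N[C@H]1COC1=O` gives 1500 nM, the nearest to compound 1 and beyond the scatter. Compound 3 `O=C(N[C@H]1COC1=O)c1ccc(OCc2ccccc2)cc1` gives 90 nM, the furthest from compound 1 and also beyond the scatter. No pair among these three differs in only one place, so no single step can be read from them.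

Compound 4 `O=C(CCc1ccccc1)NC1CCC1=O` is not yet measured. It differs from compound 1 by 2-oxocyclobutyl in place of 2-oxooxetan-3-yl on an amide-type nitrogen. Every measured compound of the series carries the 2-oxooxetan-3-yl ring, so nothing measured here shows what its removal does; the expectation below rests on that absence of precedent and on the size of the change.

The step from compound 1 to compound 4 is expected to be large and towards weaker inhibition, a 19-fold higher number from compound 1 to compound 4 (1.28 log units; beyond the scatter). For compound 4 the estimate in this assay is 8000 nM, with a likely range from 2000 nM to 30000 nM.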

Compound 4, half-maximal inhibitory concentration: > 10000000 nM
Compound 4: a limit, no number (the forecaster's own chance of this, stated with the estimate: 30%); middle value at least 1200-fold (3.09 log units) from the limit.
By their numbers in this assay, from the lowest: compound 3; then compound 1; then compound 2. At a limit, above all of these: compound 4.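

Going by these compounds alone, the step is an at least 23000-fold higher number from compound 1 to compound 4 (4.37 log units; beyond the scatter), the first single-place comparison, read in this assay. Its size rests on a limit and not on a number: the limit of > 10000000 nM in this assay, at which 1 of the 4 values shown sits. A four-membered ring on this amide-type nitrogen is therefore not enough by itself to keep the inhibition seen with compound 1, since 2-oxocyclobutyl keeps the ring size and the double bond outside aromatic rings, but has a ring of carbon only and no defined stereocentre.

The compounds shown do not separate the loss of the ring hetero atom from the loss of the defined stereocentre. Going by these compounds, it also stays open whether a sulfur or nitrogen atom in place of the ring oxygen would retain inhibition, and whether the change would act alike on the acyl parts of compound 2 and compound 3.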